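Furan to thiophene swap at the saturated ring carbon

The source may hold more compounds than are shown below. What is called first, only, known or untested is meant among the compounds shown, and "the series" means these compounds.

Compound 1 `CCCOC(=O)C1=C(C)N(C)C(=O)NC1c1ccco1` gives 23% in an assay on membranes from HEK293 cells for displacement of a labelled ligand from adenosine receptor A2b (Homo sapiens), read by scintillation counting, with a stated time of 30 min, tested at 1 uM; on this read-out lower numbers stand for less inhibition and higher numbers for more inhibition at the one concentration tested (going by the name of the read-out). Within the data shown here, compound 2 `CC1=C(C(=O)OCC(C)C)C(c2ccco2)NC(=O)N1C` gives 4% in this assay, the lower of the two numbers so far. Among the measured compounds shown here, the only measured step, a number 19 percentage points lower from compound 1 to compound 2 (beyond the scatter), lies elsewhere in the structure and does not bear on the change at hand. Compound 3 `CC1=C(C(=O)OCC(C)C)C(c2cccs2)NC(=O)N1C` differs from compound 2 by thiophen-2-yl in place of furan-2-yl on a saturated ring carbon. For the measured compounds named here, no measured step touches this part of the series, so the two numbers give no direction, and a step within the scatter is expected. Compound 3 is expected to give 8% in this assay, with a range from 0% to 25%. This corresponds to an expected step of a number 4 percentage points higher from compound 2 to compound 3 (within the scatter).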

Compound 3, a percentage reported as inhibition, at one concentration (the size of the read-out at that concentration, not a potency): 2%
Compound 3: middle estimate off by 6 percentage points, on the high side; low and high end bracket the measured number.
By their numbers in this assay, from the lowest: compounds 3 and 2 (each within the scatter of the next); then compound 1.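

In this assay, among these compounds, thiophen-2-yl in place of furan-2-yl on the saturated ring carbon gives a number 2 percentage points lower from compound 2 to compound 3 (within the scatter) with the isobutoxycarbonyl group kept, the first reading at this position. Sulfur for oxygen in the five-membered aromatic ring therefore leaves the number within the scatter, though both numbers are small, so little room remains for a further fall to show. Nothing on hand accounts for this result.

As far as these compounds go, whether a phenyl group or an aminomethyl-bearing ring at this carbon would move the number remains open. Also open, from the compounds shown here alone, is whether the same swap stays within the scatter alongside the propyl ester of compound 1.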